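The compounds below may be only part of what the source reports. "The series", "measured", "known", "first", "only" and "open" are said of these compounds alone.

Compound 3 `CCc1ccc(NC2=CC(=O)c3nc4n(c3C2=O)[C@H]2OC[C@@H](O)[C@H]2OC4)cc1` belongs to a set of three compounds that share a core and differ only in the group on the amine nitrogen. In a functional assay on HeLa cells (Homo sapiens) for inhibition, read by sulforhodamine B assay (a higher number here means a weaker inhibitor, a lower number a stronger inhibitor), compound 3 gives 3990 nM. Compound 1 `Cc1ccc(NC2=CC(=O)c3nc4n(c3C2=O)[C@H]2OC[C@@H](O)[C@H]2OC4)cc1` gives 3860 nM and compound 2 `Cc1ccc(NC2=CC(=O)c3nc4n(c3C2=O)[C@H]2OC[C@@H](O)[C@H]2OC4)cc1C` gives 2690 nM; compound 3 sits within the scatter of both, as the steps show: a 1.0-fold higher number from compound 1 to compound 3 (0.01 log units; within the scatter) and a 1.5-fold higher number from compound 2 to compound 3 (0.17 log units; within the scatter). The unmeasured compound 4 `O=C1C=C(Nc2cccc(Cl)c2)C(=O)c2c1nc1n2[C@H]2OC[C@@H](O)[C@H]2OC1` differs from compound 3 in one place: 3-chlorophenyl in place of 4-ethylphenyl on an amine nitrogen. The measured steps that bear on this change all swap one group on the same amine nitrogen, and the remaining one, a 1.4-fold lower number from compound 1 to compound 2 (0.16 log units; within the scatter), is as small as the two already named. Among the compounds with values here, none of these moved the number beyond the scatter, and none of the measured compounds carries a chlorine, so nothing among them speaks to that part of the change. The step is therefore expected to be a 1.1-fold lower number from compound 3 to compound 4 (0.02 log units; within the scatter). The estimate for compound 4 in this assay is 3800 nM, with a range from 1500 nM to 9500 nM.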

Compound 4, half-maximal inhibitory concentration: 6040 nM
Estimate against measurement, compound 4: 1.6-fold (0.20 log units) below; the measured number falls inside the stated range.
By their numbers in this assay, from the lowest: compounds 2, 1, 3 and 4 (each within the scatter of the next, the first and the last beyond it).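

In this assay, within the data shown here, replacing 3,4-dimethylphenyl with 3-chlorophenyl on the amine nitrogen gives the first step in this set that lies beyond the scatter, and it is a modest one (a 2.2-fold higher number from compound 2 to compound 4 (0.35 log units; beyond the scatter)). The other two steps to the chlorinated group remain within the scatter (a 1.5-fold higher number from compound 3 to compound 4 (0.18 log units; within the scatter); a 1.6-fold higher number from compound 1 to compound 4 (0.19 log units; within the scatter)), so 3-chlorophenyl cannot be told apart from 4-ethylphenyl or 4-methylphenyl at this position. No other measurement among the data shown accounts for these steps.

With 3-chlorophenyl the only chlorine-bearing group shown, it remains open whether the one step beyond the scatter belongs to the chlorine or to the loss of the two methyl groups. On these data alone, how the number responds to an amine, a carboxylic acid or a longer chain on the phenyl ring also remains open.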